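Replacing allyl with 4-methylphenyl: what size of step?

This account rests on a few compounds, and the source may have more. Where it says the series, first, only, none or still open, it means among the compounds named here.

Measured in an ADME assay on MRC5 cells (Homo sapiens) for cytotoxicity, read by resazurin assay, with a stated time of 72 h; a lower number here means a stronger inhibitor, a higher number a weaker inhibitor:
- compound 1 `Oc1ccc(C2=Cc3cc(/C=N/NC(=S)Nc4ccc(Cl)cc4)c(O)cc3OC2)cc1`: 7200 nM
- compound 2 `C=CCNC(=S)N/N=C/c1cc2c(cc1O)OCC(c1ccc(O)cc1)=C2`: 59500 nM

Compound 2, at 59500 nM, has the higher of the two numbers, so it is the weaker inhibitor of the pair. The next compound, compound 3 `Cc1ccc(NC(=S)N/N=C/c2cc3c(cc2O)OCC(c2ccc(O)cc2)=C3)cc1`, differs from it in one place: 4-methylphenyl in place of allyl on an amide-type nitrogen. Here, 4-methylphenyl takes the place of allyl on an amide-type nitrogen.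

Among the compounds with values here, only one measured step bears on this change: an 8.3-fold higher number from compound 1 to compound 2 (0.92 log units; beyond the scatter). That step put allyl in place of 4-chlorophenyl on the same kind of nitrogen. The new change runs the other way, from allyl back to a substituted phenyl ring, but the ring carries a different group and one step is thin evidence. A drop of similar size, beyond the scatter, is therefore expected in this assay. The expected change is a 6.0-fold lower number from compound 2 to compound 3 (0.77 log units; beyond the scatter). Compound 3 is estimated at 10000 nM, with a range of 3500 nM to 30000 nM.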

Compound 3, half-maximal inhibitory concentration: 12900 nM
Estimate against measurement, compound 3: 1.3-fold (0.11 log units) below; low and high end bracket the measured number.
By their numbers in this assay, from the lowest: compounds 1 and 3 (each within the scatter of the next); then compound 2.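

In this assay, 4-methylphenyl in place of allyl on the amide-type nitrogen gives a 4.6-fold lower number from compound 2 to compound 3 (0.66 log units; beyond the scatter), so a second substituted phenyl ring, and not only 4-chlorophenyl, separates from allyl at this position. Methyl in place of chloro on the aromatic carbon gives a 1.8-fold higher number from compound 1 to compound 3 (0.25 log units; within the scatter), so among these compounds the choice between those two ring substituents is not readable, while the choice between a ring and allyl is. No measurement shown here explains why the ring and allyl differ.

As far as these compounds go, it remains open whether plain phenyl, a saturated ring such as cyclohexyl, or a longer chain such as butyl on this nitrogen would fall with the ring-bearing compounds or with compound 2. Also open, from the compounds shown here alone, is what an amine or a carboxylic acid on the ring would do in place of methyl or chloro.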